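A few compounds are considered here, and "the series" means these few. Any claim that something is new, unique, unknown or untested is made for them only; others in the source may bear on it.

Measured in an assay on HEK293 cells for agonist activity at transient receptor potential cation channel subfamily M member 8 (Homo sapiens), read by fluorescence and calcium flux, with a stated time of 15 min; on this read-out higher numbers stand for an effect only at larger amounts of compound and lower numbers for an effect already at smaller amounts:
compound 1, `CON(Cc1cccs1)C(=O)COc1ccc(C)cc1` — compound 1 gives 10 nM
compound 2, `CCN(Cc1cccs1)C(=O)COc1ccc(C)cc1O` — compound 2 gives 8 nM
compound 3, `CCN(Cc1cccs1)C(=O)/C=C/c1ccc(C)cc1` — compound 3 gives 2 nM

Compound 1 carries the highest of the three numbers. Compound 2 lies within the scatter of compound 1, so nothing separates the two. Compound 3 lies beyond the scatter, at the lower number. No two of these compounds differ in one place only, so no single step is isolated among them; what compound 3 shows against compound 1 is a lower number and no more.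

Compound 4, `Cc1ccc(OCC(=O)N(Cc2cccs2)c2cn[nH]c2)cc1`, has not been measured. It differs from compound 1 in one place: 1H-pyrazol-4-yl in place of methoxy on an amide-type nitrogen. For the measured compounds named here, no measured pair isolates a change on the amide-type nitrogen, so the expectation rests only on the spread of the three numbers. The step from compound 1 to compound 4 is expected to be small, leaning toward a higher number, estimated as a 2.0-fold higher number from compound 1 to compound 4 (0.30 log units; within the scatter). Compound 4 is estimated at 20 nM, with a range from 4 nM to 100 nM.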

Compound 4, half-maximal effective concentration: 1.4 nM
Compound 4: the middle estimate sits 14-fold (1.15 log units) above what was measured; measured number below the stated range.
By their numbers in this assay, from the lowest: compounds 4 and 3 (each within the scatter of the next); then compounds 2 and 1 (each within the scatter of the next).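

In this assay, the amide-type nitrogen whose other neighbours are a carbonyl carbon and a saturated chain carbon accepts a ring in place of methoxy: 1H-pyrazol-4-yl gives a 7.1-fold lower number from compound 1 to compound 4 (0.85 log units; beyond the scatter), the first single-place step isolated in this series. The change brings in a five-membered aromatic ring with 2 hetero atoms and 1 hydrogen-bond donor together, and this one step does not separate their contributions. No measurement bears on what lies behind the lower number.

Open, on these data alone, is whether a phenyl ring or a saturated ring such as piperidin-4-yl on this amide-type nitrogen would give a step of similar size, which would help to separate the ring from the donor. Also open, as far as these compounds go, is whether the step carries over to the cores of compound 2 and compound 3.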